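This account rests on a few compounds, and the source may have more. Where it says the series, first, only, none or still open, it means among the compounds named here.

Compound 1 `Oc1ccc(-c2cc(-c3ccc(Cl)cc3)nc(-c3cccs3)c2)cc1`: 38.8%
Compound 2 `Oc1ccc(-c2cc(-c3ccc(Cl)cc3)nc(-c3ccsc3)c2)cc1`: 47.7%

For the measured compounds named here, in an assay on isolated protein for inhibition of DNA topoisomerase 1 (Homo sapiens), with a stated time of 30 min, tested at 100 uM (a higher number here means a stronger effect of the compound at the concentration tested, a lower number a weaker effect), compound 2 gives 47.7%, which places it at the top of the two numbers recorded; the single measured step, a number 8.9 percentage points higher from compound 1 to compound 2 (within the scatter), lies within the scatter, so no real gap between compound 1 and compound 2 is established. Compound 3 `Oc1ccc(-c2cc(-c3ccsc3)nc(-c3cccc(Cl)c3)c2)cc1` is built from the same atoms as compound 2, joined differently, and differs from it in one place: 3-chlorophenyl in place of 4-chlorophenyl on an aromatic carbon. Going by the values given here, the only measured step, a number 8.9 percentage points higher from compound 1 to compound 2 (within the scatter), concerns the thiophene and not the chlorophenyl, so no measured step bears directly on this change; with only two values in hand and both within the scatter of each other, there is no basis for expecting a move in either direction. The expected step from compound 2 to compound 3 is therefore a number 2.7 percentage points lower from compound 2 to compound 3 (within the scatter), none beyond the scatter. Compound 3 is estimated at 45%, with a range from 25% to 65%.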

Compound 3, a percentage reported as inhibition, at one concentration (the size of the read-out at that concentration, not a potency): 26%
Compound 3: middle estimate off by 19 percentage points, on the high side; measured number inside the range.
By their numbers in this assay, from the lowest: compound 3; then compounds 1 and 2 (each within the scatter of the next).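

In this assay, the place of the chlorine on the phenyl group next to the ring nitrogen proves to matter: 3-chlorophenyl in place of 4-chlorophenyl gives a number 21.7 percentage points lower from compound 2 to compound 3 (beyond the scatter), even though the group that leaves and the group that enters hold the same atoms. For the compounds shown here, the earlier compounds showed only a change at the thiophene, with no gap beyond the scatter, so this is the first position where a single change separates two compounds. Nothing measured here explains the step.

Going by these compounds, whether the same swap has a comparable effect alongside the thiophen-2-yl group of compound 1 remains open. So does how this place would respond to a phenyl group carrying an amine or a carboxylic acid instead of chlorine.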